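This account rests on a few compounds, and the source may have more. Where it says the series, first, only, none or still open, it means among the compounds named here.

Of the compounds shown here, two have so far been measured in a functional assay on MOLT-4 cells (Homo sapiens) for antiproliferative activity, read by cell counting, with a stated time of 2 days; on this read-out lower numbers stand for stronger inhibition and higher numbers for weaker inhibition. Compound 1 `Cc1ccc(Nc2nc(N)c(C(=O)c3ccccc3)s2)cc1` gives 210 nM, the lowest of the two numbers. Compound 2 `COc1ccc(Nc2nc(N)c(C(=O)c3cc(OC)c(OC)c(OC)c3)s2)cc1` gives 480 nM, a weaker result that lies beyond the usual scatter. Compound 3 `COc1ccc(Nc2nc(N)c(C(=O)c3ccccc3)s2)cc1` has not yet been measured; it differs from compound 1 by methoxy in place of methyl on an aromatic carbon. Compound 2 also carries methoxy groups but differs in other ways as well, so it offers only loose guidance. The step of a 1.4-fold higher number from compound 1 to compound 3 (0.15 log units; within the scatter) is expected to be small, within the scatter or slightly weaker. Compound 3 is therefore estimated at 300 nM, with a range of 120 nM to 800 nM.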

Compound 3, half-maximal inhibitory concentration: 230 nM
Compound 3: the middle estimate sits 1.3-fold (0.12 log units) above what was measured, within the range that was stated.
By their numbers in this assay, from the lowest: compounds 1 and 3 (each within the scatter of the next); then compound 2.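

In this assay methoxy in place of methyl on an aromatic carbon, para to a large group, gives a 1.1-fold higher number from compound 1 to compound 3 (0.04 log units; within the scatter) and so stays within the scatter. For the compounds shown here, this is the first single-change comparison at this position, and it shows that the added oxygen and hydrogen-bond acceptor leave the number essentially unmoved here. No supporting measurement is available to explain this match.

From the compounds shown here alone, whether an amine, a chlorine atom or a longer chain such as butyl at this position would also leave the number in place stays open. So does the effect of a single change elsewhere on the core of compound 1.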